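From cyano to carboxy, starting from a limit

The source may hold more compounds than are shown below. What is called first, only, known or untested is meant among the compounds shown, and "the series" means these compounds.

Measured in a functional assay on Caco-2 cells (Homo sapiens) for antiproliferative activity, with a stated time of 48 h; a lower number here means a stronger inhibitor, a higher number a weaker inhibitor:
- compound 1 `COc1ccc(Nc2ccc(-c3ccccc3)nn2)cc1`: 50000 nM
- compound 2 `CCN(CC)c1ccc(-c2ccc(C#N)cc2)nn1`: > 25000 nM (a limit)

In this assay, compound 2 has no number, only a limit: > 25000 nM. Compound 3 `CCN(CC)c1ccc(-c2ccc(C(=O)O)cc2)nn1` is compound 2 with carboxy in place of cyano on an aromatic carbon, para to a large group: carboxy in place of cyano on an aromatic carbon. Within the data shown here, no pair of measured compounds differs in one place, so the data offer no measured step to serve as a guide. The expectation therefore rests on compound 1, at 50000 nM, and on (the limit of > 25000 nM in this assay, at which 1 of the 2 values shown sits). No change beyond the usual scatter is expected, and if any change appears, the expected direction is toward a weaker inhibitor. The estimated move is a step that the limit leaves unreadable from compound 2 to compound 3. For compound 3, the expected value is 40000 nM, with an estimated range of 15000 nM to 100000 nM.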

Compound 3, half-maximal inhibitory concentration: > 25000 nM
Compound 3 was reported as a limit (the forecaster's own chance of this, stated with the estimate: 50%); the middle value is on the limit's open side.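

Among these compounds, compound 2 and compound 3 are both reported only as limits in this assay, and no step between them can be read. The compounds shown leave open how strong an inhibitor either compound is, and whether carboxy in place of cyano changes that strength at all.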